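Replacing a sulfonamide with a sulfone in a shared core

A few compounds are considered here, and "the series" means these few. Any claim that something is new, unique, unknown or untested is made for them only; others in the source may bear on it.

Of the compounds shown here, three with a shared core have so far been measured in a functional assay on the whole organism (aorta) with Rattus norvegicus as the target; on this read-out lower numbers stand for smaller maximal responses and higher numbers for larger maximal responses. Compound 1, `CCNS(=O)(=O)c1ccc2c(c1)C(n1ccccc1=O)=CC(C)(C)O2`, gives 72.4%. Compound 2, `CC1(C)C=C(n2ccccc2=O)c2cc(S(=O)(=O)Nc3ccc(C#N)cc3)ccc2O1`, gives 84%. Compound 3, `CN(c1ccccc1)S(=O)(=O)c1ccc2c(c1)C(n1ccccc1=O)=CC(C)(C)O2`, gives 64.2%. Among these three numbers compound 3 stands lowest: the gap to compound 1 lies within the scatter, while the gap to compound 2 lies beyond it.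

The step now followed leads to compound 4, `CC1(C)C=C(n2ccccc2=O)c2cc(S(=O)(=O)c3ccccc3)ccc2O1`, which has not yet been measured. The change is phenyl in place of methyl(phenyl)amino on a sulfonyl sulfur.

All three measured steps also alter the group carried on the sulfonyl sulfur. The step of a number 11.6 percentage points higher from compound 1 to compound 2 (beyond the scatter) and the step of a number 19.8 percentage points lower from compound 2 to compound 3 (beyond the scatter) were both modest, and the step of a number 8.2 percentage points lower from compound 1 to compound 3 (within the scatter) stayed within the scatter. Among the compounds with values here, none of these steps removes the nitrogen from the sulfonyl sulfur, so no measured pair speaks directly to this change, but every change at this position so far has moved the number by only a modest amount.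

A modest step is therefore expected for compound 4, most likely upward toward the middle of the measured numbers, amounting to a number 5.8 percentage points higher from compound 3 to compound 4 (within the scatter). Compound 4 is estimated to give 70%, within a range from 55% to 88%.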

Compound 4, largest response reached (Emax), in percent of the reference or control that the assay uses: 79.3%
Compound 4: middle estimate off by 9.3 percentage points, on the low side, and the stated range covers the measured number.
By their numbers in this assay, from the lowest: compounds 3, 1, 4 and 2 (each within the scatter of the next, the first and the last beyond it).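

With phenyl placed directly on the sulfonyl sulfur, no nitrogen remains at this position, and in this assay the result is a number 15.1 percentage points higher from compound 3 to compound 4 (beyond the scatter). Taking out the nitrogen therefore does not pull the number down: a number 4.7 percentage points lower from compound 2 to compound 4 (within the scatter) and a number 6.9 percentage points higher from compound 1 to compound 4 (within the scatter), so a sulfonyl sulfur without nitrogen performs on a par with the (4-cyanophenyl)amino and ethylamino groups. No other measurement bears on why phenyl stands higher than methyl(phenyl)amino.

As far as these compounds go, every group seen on the sulfonyl sulfur so far is either an amino group carrying ethyl or an aromatic ring, or a bare phenyl, so it remains open whether a plain methyl or a longer alkyl chain attached directly to the sulfur would give a similar number. From the compounds shown here alone, it is also open how a 4-cyanophenyl attached directly to the sulfur would compare with the (4-cyanophenyl)amino group of compound 2, a pairing that would show the effect of the nitrogen with the ring held the same.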